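DPP-4 inhibition: pyrrolidine amide series

The source may report more compounds than this note shows. Statements on the series, on what has been measured and on what is new or still open speak of the compounds shown alone.

Measured compounds:
compound 1 `CCN(CC)C(=O)[C@@H]1CN[C@H](C(=O)N2CCC[C@H]2C#N)C1`: 43%
compound 2 `CN(C)C(=O)[C@@H]1CN[C@H](C(=O)N2CCC[C@H]2C#N)C1`: 76%

Both compounds share a core bearing a cyanopyrrolidine amide; they differ only in the amide at the carbonyl carbon. In an assay on the whole organism (plasma, strain Sprague-Dawley) for inhibition of Dipeptidyl peptidase 4 (Rattus norvegicus), with a stated time of 6 h, at a dose of 1 mg/kg by the oral route (on this read-out lower numbers stand for less inhibition and higher numbers for more inhibition at the one dose given (going by the name of the read-out)), compound 1 gives 43% and compound 2 gives 76%. Going by the values given here, the one measured step, a number 33 percentage points higher from compound 1 to compound 2 (beyond the scatter), concerns dimethylamino in place of diethylamino on a carbonyl carbon. Compound 2 therefore stands highest of the two numbers, with compound 1 nearest and the step beyond the scatter.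

Compound 3 `N#C[C@@H]1CCCN1C(=O)[C@@H]1C[C@H](CCO)CN1` has not been measured. It differs from compound 2 as follows: 2-hydroxyethyl in place of dimethylcarbamoyl on a saturated ring carbon. The measured step bears on this change only indirectly: it shows that the group at this ring carbon can move the read-out by a large amount, but it swaps one carbamoyl for another, while here the whole dimethylcarbamoyl is gone and a 2-hydroxyethyl enters. Among the compounds with values here, no measured pair tests such a replacement. For compound 3 in this assay the step of a number 26 percentage points lower from compound 2 to compound 3 (beyond the scatter) is expected with wide uncertainty, leaning lower. Compound 3 is thus estimated at 50%, in the range 20% to 80%.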

Compound 3, a percentage reported as inhibition, in the whole organism at one dose (the size of the read-out at that dose, not a potency): 64%
Compound 3: middle estimate off by 14 percentage points, on the low side; low and high end bracket the measured number.
By their numbers in this assay, from the lowest: compound 1; then compound 3; then compound 2.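

In this assay the saturated ring carbon also accepts a group without a carbonyl or an amide nitrogen: 2-hydroxyethyl in place of dimethylcarbamoyl gives a number 12 percentage points lower from compound 2 to compound 3 (beyond the scatter), while 2-hydroxyethyl in place of diethylcarbamoyl gives a number 21 percentage points higher from compound 1 to compound 3 (beyond the scatter). A carbamoyl at this position is therefore not needed for a read-out above that of compound 1, and the change from a carbamoyl to 2-hydroxyethyl can move the number in either direction, depending on which carbamoyl leaves. Nothing available explains this order of the three compounds.

Still open, on these data alone, is whether the read-out of compound 3 follows the terminal hydroxyl or the two-carbon chain, which a methoxyethyl group, a longer 3-hydroxypropyl chain, a 2-aminoethyl group or a carboxylic acid at the same ring carbon would help separate. The read-out also reflects a single oral dose at a single time, so this order says nothing about potency or about how the three compounds would compare at other doses or times.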